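Swapping a Bromophenyl for a Heptyl Chain

This account rests on a few compounds, and the source may have more. Where it says the series, first, only, none or still open, it means among the compounds named here.

Measured compounds:
compound 1 `O=C(CN1CCC(Cc2ccccc2)CC1)Nc1ccc(C(=O)/C=C/c2cn(Cc3ccc(Br)cc3)nn2)cc1` gives 41900 nM
compound 2 `CCCCCCCCCCn1cc(/C=C/C(=O)c2ccc(NC(=O)CN3CCN(C(=O)OC(C)(C)C)CC3)cc2)nn1` gives 30200 nM
compound 3 `CC(C)(C)OC(=O)N1CCN(CC(=O)Nc2ccc(C(=O)/C=C/c3cn(Cc4ccc(Br)cc4)nn3)cc2)CC1` gives 18900 nM

All three were tested in a functional assay on HeLa cells (Homo sapiens) for inhibition, read by MTT assay; on this read-out lower numbers stand for stronger inhibition and higher numbers for weaker inhibition. Compound 1 stands at the highest of the three numbers. Compound 2 lies within the scatter of compound 1, so the two cannot be told apart, while compound 3 sits beyond the scatter, the lowest of the three.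

Compound 4 `CCCCCCCCn1cc(/C=C/C(=O)c2ccc(NC(=O)CN3CCC(Cc4ccccc4)CC3)cc2)nn1` has not yet been measured. It differs from compound 1 in one place:
heptyl in place of 4-bromophenyl on a saturated chain carbon bound to an aromatic nitrogen

One measured step speaks to this change, though it runs the other way round: a 1.6-fold lower number from compound 2 to compound 3 (0.20 log units; within the scatter). There, 4-bromophenyl in place of nonyl left the number within the scatter. Read backwards, putting heptyl where 4-bromophenyl was would be expected to leave the number roughly where it is, or nudge it a little upward, but not beyond the scatter. Compound 4 is therefore estimated at 55000 nM, with a range from 25000 nM to 120000 nM. That estimate amounts to an expected step of a 1.3-fold higher number from compound 1 to compound 4 (0.12 log units; within the scatter).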

Compound 4, half-maximal inhibitory concentration: 78600 nM
Estimate against measurement, compound 4: 1.4-fold (0.16 log units) below; the range from low to high includes it.
By their numbers in this assay, from the lowest: compounds 3, 2, 1 and 4 (each within the scatter of the next, the first and the last beyond it).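

In this assay the exchange of the ring for the chain gives a 1.9-fold higher number from compound 1 to compound 4 (0.27 log units; within the scatter) and so, in this pair, 4-bromophenyl and heptyl, each of 7 heavy atoms, cannot be told apart on a saturated chain carbon bound to an aromatic nitrogen. The earlier pair showed a 1.6-fold lower number from compound 2 to compound 3 (0.20 log units; within the scatter) with nonyl as the chain and a different remainder of the molecule, so a ring-for-chain exchange at this place has now stayed within the scatter in two settings, and neither pair goes against that reading. Nothing available explains why the number responds so little to this exchange.

Still open, from the compounds shown here alone, is whether a plain phenyl without the bromine, or a 4-methoxyphenyl, would behave as 4-bromophenyl does at this place. Going by these compounds, it is equally open whether a much shorter chain such as butyl, or a chain ending in an amine or a carboxylic acid, would carry the number beyond the scatter in either direction.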